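Replacing the Aromatic Amide Ring with a Saturated One

A few compounds are considered here, and "the series" means these few. Any claim that something is new, unique, unknown or untested is made for them only; others in the source may bear on it.

Compound 3 `CN1CCN(c2ccc(Nc3nc(-c4cccc(NC(=O)c5ccc(Cl)cc5)c4)sc3C(N)=O)cc2)CC1` stands highest of the three numbers in a functional assay on Ramos cells (Homo sapiens) for antiproliferative activity, read by CCK-8 assay, with a stated time of 72 h, tested at 40 uM (on this read-out higher numbers stand for more inhibition at the one concentration tested (going by the name of the read-out) and lower numbers for less inhibition), but its nearest neighbour, compound 2 `CN1CCN(c2ccc(Nc3nc(-c4cccc(NC(=O)c5ccccc5)c4)sc3C(N)=O)cc2)CC1`, gives 98.1%, and compound 1 `CN1CCN(c2ccc(Nc3nc(-c4cccc(NC(=O)c5ccc(F)cc5)c4)sc3C(N)=O)cc2)CC1` gives 95.9%, so that compound 3 at 99% is separated from both only within the scatter: a number 0.9 percentage points higher from compound 2 to compound 3 (within the scatter) and a number 3.1 percentage points higher from compound 1 to compound 3 (within the scatter). The remaining step, a number 2.2 percentage points higher from compound 1 to compound 2 (within the scatter), is likewise within the scatter. Compound 4 `CN1CCN(c2ccc(Nc3nc(-c4cccc(NC(=O)[C@H]5CC[C@H](C)CC5)c4)sc3C(N)=O)cc2)CC1` differs from compound 3 by 4-methylcyclohexyl in place of 4-chlorophenyl on a carbonyl carbon. None of the three measured steps bears directly on this change; all of them exchange a substituent on an aromatic ring that is itself retained, whereas here the aromatic ring gives way to a non-aromatic one. Going by the values given here, the measured steps show only that the three amide rings tested so far all sit near the top of this assay. An estimate must therefore lean on that ceiling: compound 4 is expected at 88%, within 65% to 99%, which would mean a step of a number 11 percentage points lower from compound 3 to compound 4 (beyond the scatter), more likely downward than upward but not confidently beyond the scatter.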

Compound 4, a percentage reported as inhibition, at one concentration (the size of the read-out at that concentration, not a potency): 55.1%
For compound 4 the middle estimate is 32.9 percentage points above the measured one, and the stated range ends above it.
By their numbers in this assay, from the lowest: compound 4; then compounds 1, 2 and 3 (each within the scatter of the next).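

In this assay the group on the carbonyl carbon proves able to move the number after all, with a number 43.9 percentage points lower from compound 3 to compound 4 (beyond the scatter) and a number 43 percentage points lower from compound 2 to compound 4 (beyond the scatter) and also a number 40.8 percentage points lower from compound 1 to compound 4 (beyond the scatter) whichever of the aromatic groups is taken as the starting point. The earlier exchanges, all made on a retained aromatic ring, gave no sign of this. The high numbers of compounds 1, 2 and 3 therefore hold for those aromatic amides and do not extend to compound 4, with its non-aromatic ring of carbon only.

As far as these compounds go, whether the fall belongs to the saturated ring itself or to its methyl stays open, as does how an unsubstituted cyclohexyl, a piperidine or a short open chain such as ethyl would read on this carbonyl carbon. Nothing at hand explains the fall.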